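The source may hold more compounds than are shown below. What is called first, only, known or untested is meant among the compounds shown, and "the series" means these compounds.

Three compounds share one core and differ only in the group attached to the carbonyl carbon of the amide. Compound 1 `CN(C)c1cc2[nH]c(C3CCCCC3)nc2cc1NC(=O)c1ccco1` carries a furan-2-yl there, compound 2 `Cc1ccc(C(=O)Nc2cc3nc(C4CCCCC4)[nH]c3cc2N(C)C)cc1` a 4-methylphenyl, and compound 3 `CN(C)c1cc2[nH]c(C3CCCCC3)nc2cc1NC(=O)c1ccc(F)cc1` a 4-fluorophenyl. In an ADME assay on Vero cells (Chlorocebus sabaeus) for cytotoxicity, read by resazurin assay, with a stated time of 3 days (on this read-out lower numbers stand for stronger inhibition and higher numbers for weaker inhibition), compound 1 gives > 100 ug/mL, which is a limit of the assay rather than a number. Compound 2 likewise gives > 100 ug/mL, again a limit. Compound 3 gives > 100 ug/mL, also a limit. The steps a step that the two limits leave unreadable from compound 1 to compound 2, a step that the two limits leave unreadable from compound 1 to compound 3 and a step that the two limits leave unreadable from compound 2 to compound 3 are therefore unreadable in size. Compound 3 thus stands at the limit of > 100 ug/mL in this assay, at which 3 of the 3 values shown sit, together with every other value shown.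

Compound 4 `CN(C)c1cc2[nH]c(C3CCCCC3)nc2cc1NC(=O)c1ccc(F)cc1F` differs from compound 3 by fluoro in place of hydrogen on an aromatic carbon. No measured step can be read for size, so no direction can be drawn from them; all three measured compounds sit at the same limit. Compound 4 is therefore expected to remain at that limit as well, an expected step that the limit leaves unreadable from compound 3 to compound 4. The estimate for compound 4 is 150 ug/mL, with a range from 50 ug/mL to 500 ug/mL.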

Compound 4, half-maximal inhibitory concentration: > 100 ug/mL
Compound 4 ended at the assay's limit; the forecaster's own chance of this, stated with the estimate: 85%; the middle value lies beyond the limit too.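

Compound 4 sits at the same limit as compound 1, compound 2 and compound 3, so none of its steps to them can be read for size: the limit of > 100 ug/mL in this assay, at which 4 of the 4 values shown sit. The compounds shown leave open whether any group on the carbonyl carbon changes the cytotoxicity read-out at all, and by how much.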